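The source may hold more compounds than are shown below. What is called first, only, known or untested is meant among the compounds shown, and "the series" means these compounds.

Measured in an assay on HEK293 cells for displacement of a labelled ligand from 5-hydroxytryptamine receptor 7 (Rattus norvegicus); on this read-out lower numbers stand for stronger inhibition and higher numbers for weaker inhibition:
compound 1, `COc1ccccc1N1CCN(CC(=O)NC2CCCc3c(OC)cccc32)CC1`, a limit of the assay only: > 1000 nM
compound 2, `COc1ccccc1N1CCN(CCCC(=O)NC2CCCc3c(OC)cccc32)CC1`: 35 nM
compound 3, `COc1ccc2c(c1)C(NC(=O)CCCCN1CCN(c3ccccc3OC)CC1)CCC2`: 38.4 nM

Compound 2 and compound 3 give numbers that lie within the scatter of each other in this assay, so no order between the two is claimed. Compound 1 gives only a limit of this assay and no number (the limit of > 1000 nM in this assay, at which 1 of the 3 values shown sits). Among the measured compounds shown here, no two of the measured compounds differ in a single place, so no measured single-point step exists.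

Compound 4, `COc1ccccc1N1CCN(CCCC(=O)NC2CCCc3ccccc32)CC1`, is still to be measured in this assay. It differs from compound 2 in one place: hydrogen in place of methoxy on an aromatic carbon. For the measured compounds named here, with no measured step of this kind at hand, the size of the change in this assay cannot be read from compound 2 and compound 3; the expectation is for a small step toward a higher number, of a size near or only slightly beyond the scatter. The estimate for compound 4 in this assay is 55 nM, with a range from 20 nM to 160 nM. The step expected from compound 2 to compound 4 is a 1.6-fold higher number from compound 2 to compound 4 (0.20 log units; within the scatter).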

Compound 4, inhibition constant: 92 nM
The estimate for compound 4 lay 1.7-fold (0.22 log units) below the measured number; low and high end bracket the measured number.
By their numbers in this assay, from the lowest: compounds 2 and 3 (each within the scatter of the next); then compound 4. At a limit, above all of these: compound 1.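

In this assay the series now has its first measured single-place step, a 2.6-fold higher number from compound 2 to compound 4 (0.42 log units; beyond the scatter), for hydrogen in place of methoxy on an aromatic carbon, ortho to a fused ring and meta to a fused ring. The earlier compounds shown here could not separate the contribution of this methoxy from that of the rest of the structure; here the methoxy counts for a modest but real part of the read-out, and the step lies beyond the scatter, while compound 4 still gives a measured 92 nM rather than a limit of the assay, so the group is not required for a measurable number. Nothing among the data shown accounts for the size of this step.

As far as these compounds go, whether the step belongs to methoxy itself remains open, since a fluorine, a hydroxyl, an ethoxy group or an amine on the same aromatic carbon would be needed to tell this apart from a general need for any substituent there. From the compounds shown here alone, it is also open whether the same replacement gives a step of similar size on a longer chain between the amide carbonyl and the piperazine-bearing end of the molecule.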